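Benzyl substituent change on an aminopyridine-bearing thienopyrimidinone

A few compounds are considered here, and "the series" means these few. Any claim that something is new, unique, unknown or untested is made for them only; others in the source may bear on it.

Three compounds sharing one core were measured in an assay on isolated protein for inhibition of Rho-associated protein kinase 1 (Homo sapiens), read by radiometric assay and 33P incorporation, with a stated time of 40 min, in the presence of a further agent that is not named here; a lower number here means a stronger inhibitor, a higher number a weaker inhibitor. Compound 1 `COc1cccc(Cn2cnc3sc(-c4ccnc(N)c4)cc3c2=O)c1` gives 18 nM. Compound 2 `O=c1c2cc(-c3ccnc4[nH]ccc34)sc2ncn1Cc1cccc(C(F)(F)F)c1`, which carries a trifluoromethyl on its benzyl ring but a different group on the core, gives 110 nM. Compound 3 `Nc1cc(-c2cc3c(=O)n(Cc4cccc(F)c4)cnc3s2)ccn1` gives 34 nM, the second highest of the three numbers; its nearest neighbour is compound 1, and the single listed step a 1.9-fold higher number from compound 1 to compound 3 (0.28 log units; within the scatter) lies within the scatter, while its gap to compound 2 is beyond it.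

Compound 4 `Nc1cc(-c2cc3c(=O)n(Cc4cccc(C(F)(F)F)c4)cnc3s2)ccn1` is not yet measured. It differs from compound 3 by trifluoromethyl in place of fluoro on an aromatic carbon. Going by the values given here, no measured step exchanges fluoro for trifluoromethyl on an otherwise identical compound. Among the compounds with values here, the one step that is known, from compound 1 to compound 3, swaps methoxy for fluoro at the same carbon and shows no change beyond the scatter, so the benzyl substituent appears tolerant to exchange in this small set. Compound 2 shows that a trifluoromethyl-bearing benzyl group is compatible with activity in this assay, but its other difference prevents any step being read from it.

Compound 4 is therefore expected to show a step of a 1.5-fold higher number from compound 3 to compound 4 (0.17 log units; within the scatter) that stays near the scatter, and its estimated value is 50 nM, within 15 nM to 160 nM.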

Compound 4, half-maximal inhibitory concentration: 490 nM
Estimate against measurement, compound 4: 9.8-fold (0.99 log units) below, and the stated range ends below it.
By their numbers in this assay, from the lowest: compounds 1 and 3 (each within the scatter of the next); then compound 2; then compound 4.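

In this assay, the carbon on the benzyl ring meta to a large group does not accept every exchange: trifluoromethyl there gives a 14-fold higher number from compound 3 to compound 4 (1.16 log units; beyond the scatter) and, set against methoxy, a 27-fold higher number from compound 1 to compound 4 (1.43 log units; beyond the scatter), although methoxy and fluoro at this carbon could not be told apart. The other place on the molecule also matters, since with the trifluoromethyl benzyl group held constant, putting the single-ring group of compound 4 in place of the two-ring group of compound 2 gives a 4.5-fold higher number from compound 2 to compound 4 (0.65 log units; beyond the scatter), so compound 2 had hidden part of the cost of trifluoromethyl at this carbon. Nothing in the data explains the size of these steps.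

On these data alone, whether a chloro or a methyl group at this carbon would stay with methoxy and fluoro or move towards trifluoromethyl remains open. So does whether the step between the two groups on the core would keep its size and direction with methoxy or fluoro on the benzyl ring.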